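A propanoylaminopropyl chain on a hydroxyl of compound 2

The source may hold more compounds than are shown below. What is called first, only, known or untested is meant among the compounds shown, and "the series" means these compounds.

Among the compounds with values here, compound 2 `CC[C@H]1OC(=O)[C@H](C)[C@@H](O)[C@H](C)[C@@H](O[C@@H]2O[C@H](C)C[C@H](N(C)C)[C@H]2O)[C@](C)(O)C[C@@H](C)CN(C)[C@H](C)[C@@H](O)[C@]1(C)O` gives 1.35 in a physicochemical assay for lipophilicity, read by HPLC, measured as chromatographic lipophilicity, at pH 7.4 (on this read-out higher numbers stand for higher lipophilicity and lower numbers for lower lipophilicity), the second highest of the three numbers known. Compound 3 `CC[C@H]1OC(=O)[C@H](C)[C@@H](O)[C@H](C)[C@@H](O)[C@](C)(O)C[C@@H](C)CN(C)[C@H](C)[C@@H](O)[C@]1(C)O` gives 1.29, and the step of a number 0.06 log units lower from compound 2 to compound 3 (within the scatter). Compound 1 `CC[C@H]1OC(=O)[C@H](C)[C@@H](O[C@H]2C[C@@](C)(OC)[C@@H](O)[C@H](C)O2)[C@H](C)[C@@H](O[C@@H]2O[C@H](C)C[C@H](N(C)C)[C@H]2O)[C@](C)(O)C[C@@H](C)CN(CCCNC(=O)c2c(C)nn(C)c2Cl)[C@H](C)[C@@H](O)[C@]1(C)O` gives 2.2, but it differs from compound 2 in more than one place, so only the two values can be set side by side. Compound 4 `CCC(=O)NCCCO[C@H]1[C@H](C)[C@@H](O[C@@H]2O[C@H](C)C[C@H](N(C)C)[C@H]2O)[C@](C)(O)C[C@@H](C)CN(C)[C@H](C)[C@@H](O)[C@](C)(O)[C@@H](CC)OC(=O)[C@@H]1C` differs from compound 2 by 3-(propanoylamino)propyl in place of hydrogen on an oxygen on a saturated carbon. Within the data shown here, no measured step carries this change, and the one measured step stays within the scatter, so it gives no direct guide. Resting on the value of compound 2 1.35, compound 4 is expected to give 1.8, between 1.4 and 2.3, an expected upward step a number 0.45 log units higher from compound 2 to compound 4 (beyond the scatter) beyond the scatter.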

Compound 4, distribution coefficient: 1.6
The estimate for compound 4 lay 0.20 log units above the measured number; the measured number falls inside the stated range.
By their numbers in this assay, from the lowest: compounds 3, 2 and 4 (each within the scatter of the next, the first and the last beyond it); then compound 1.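

In this assay, the 3-(propanoylamino)propyl chain on this oxygen on a saturated carbon gives a number 0.25 log units higher from compound 2 to compound 4 (within the scatter) and so stays within the scatter. Within the data shown here, the earlier step, a number 0.06 log units lower from compound 2 to compound 3 (within the scatter), concerned a different oxygen and a group leaving, so this is the first reading of a chain entering at this hydroxyl. Nothing measured here accounts for the size of this step.

On these data alone, whether an amine, a carboxylic acid or a longer chain on this oxygen would move the number beyond the scatter remains open. So does the share of the propanoyl end and of the propyl part in this step.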